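The source may hold more compounds than are shown below. What is called first, only, known or untested is meant among the compounds shown, and "the series" means these compounds.

Measured in a functional assay on OVCAR-5 cells (Homo sapiens) for cytotoxicity, read by sulforhodamine B assay, with a stated time of 48 h; on this read-out higher numbers stand for weaker inhibition of growth and lower numbers for stronger inhibition of growth:
- compound 1 `COc1cc(C(=O)c2ccc(OC)c(O)c2OC)cc(OC)c1O`: 4920 nM
- compound 2 `COc1cc(C(=O)c2ccc3c(c2)oc(=O)n3S(C)(=O)=O)cc(OC)c1OC`: 5770 nM

Compound 1 and compound 2 lie within the scatter of each other, so neither ranks ahead in this assay. Compound 3 `COc1ccc(C(=O)c2cc(OC)c(OC)c(OC)c2)c(OC)c1O` departs from compound 1 by methyl in place of hydrogen on an oxygen on an aromatic ring, that is, hydroxy to methoxy. Among the measured compounds shown here, no measured pair shows this change, so the expectation is loose: a sizeable move towards stronger inhibition of growth. The expected step is a 9.8-fold lower number from compound 1 to compound 3 (0.99 log units; beyond the scatter). Compound 3 is estimated at 500 nM, with a range of 60 nM to 4000 nM.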

Compound 3, concentration for 50% growth inhibition: 651 nM
Compound 3: middle estimate off by 1.3-fold (0.11 log units), on the low side; the range from low to high includes it.
By their numbers in this assay, from the lowest: compound 3; then compounds 1 and 2 (each within the scatter of the next).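

In this assay, among the compounds shown here, hydroxy to methoxy gives a 7.6-fold lower number from compound 1 to compound 3 (0.88 log units; beyond the scatter), the first step that lies beyond the scatter. Methyl in place of hydrogen on this oxygen is therefore tolerated here and goes with stronger inhibition of growth, which the earlier pair, differing in more than one place, could not show. Nothing available accounts for the step.

As far as these compounds go, it remains open whether an ethoxy group, a longer chain or an amine at this place would keep the gain. Also open, from the compounds shown here alone, is whether the same change would give a similar step on another core.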